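Swapping a Ring Group in a Cytotoxicity Series

The source may hold more compounds than are shown below. What is called first, only, known or untested is meant among the compounds shown, and "the series" means these compounds.

Compound 1, `NS(=O)(=O)c1ccc(N2N=C(c3ccc(OCc4ccccc4)cc3)CC2c2ccccc2Cl)cc1`, in an ADME assay on Vero 76 cells (Chlorocebus sabaeus) for cytotoxicity, read by MTT assay, with a stated time of 96 h (a lower number here means that less compound is tolerated, a higher number that more compound is tolerated), gives 92000 nM.
Compound 2, `Cc1ccc(C2CC(c3ccc(OCc4ccccc4)cc3)=NN2c2ccc(S(N)(=O)=O)cc2)cc1`, in this assay gives 100000 nM.
Compound 3, `Cc1ccc(C2CC(c3ccc(Oc4ccccc4)cc3)=NN2c2ccc(S(N)(=O)=O)cc2)cc1`, in this assay gives 86000 nM.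

These three compounds share a core and differ in two places. The difference between compound 2 and compound 3 is phenyl in place of benzyl on an oxygen on an aromatic ring, and the step there is a 1.2-fold lower number from compound 2 to compound 3 (0.07 log units; within the scatter). Between compound 2 and compound 1 the change is 2-chlorophenyl in place of 4-methylphenyl on a saturated ring carbon, which produced a 1.1-fold lower number from compound 2 to compound 1 (0.04 log units; within the scatter). Compound 4, `NS(=O)(=O)c1ccc(N2N=C(c3ccc(Oc4ccccc4)cc3)CC2c2ccccc2Cl)cc1`, has not yet been measured; it differs from compound 3 by 2-chlorophenyl in place of 4-methylphenyl on a saturated ring carbon, the same change at the same place as before. Because that earlier change gave a 1.1-fold lower number from compound 2 to compound 1 (0.04 log units; within the scatter), the step in this assay is expected to be small again, about a 1.1-fold lower number from compound 3 to compound 4 (0.03 log units; within the scatter). Compound 4 is therefore estimated at 80000 nM, plausibly between 45000 nM and 150000 nM.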

Compound 4, half-maximal cytotoxic concentration: 29000 nM
Estimate against measurement, compound 4: 2.8-fold (0.44 log units) above, outside the stated range (below it).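

In this assay, 2-chlorophenyl in place of 4-methylphenyl on the saturated ring carbon did not carry over from one core to the other, giving a 3.0-fold lower number from compound 3 to compound 4 (0.47 log units; beyond the scatter), against the earlier step: the same change on two cores in this assay, a 1.1-fold lower number (0.04 log units; within the scatter) from compound 2 to compound 1 and a 3.0-fold lower number (0.47 log units; beyond the scatter) from compound 3 to compound 4, 2.7-fold (0.44 log units) apart, beyond the scatter of two such steps. Phenyl in place of benzyl on the oxygen did not carry over either, giving a 3.2-fold lower number from compound 1 to compound 4 (0.50 log units; beyond the scatter), against its earlier step: the same change on two cores in this assay, a 1.2-fold lower number (0.07 log units; within the scatter) from compound 2 to compound 3 and a 3.2-fold lower number (0.50 log units; beyond the scatter) from compound 1 to compound 4, 2.7-fold (0.44 log units) apart, beyond the scatter of two such steps. This shows that each change had a larger effect only when the two were combined in compound 4, but four compounds cannot show why, or whether this holds on other cores.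

As far as these compounds go, it remains open how compound 4's core would respond to other groups on that saturated ring carbon, such as an unsubstituted phenyl or a methoxyphenyl.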